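The source may report more compounds than this note shows. Statements on the series, on what has been measured and on what is new or still open speak of the compounds shown alone.

Working notes on the series. Three compounds carry a number in a functional assay on FM3A cells (Mus musculus) for inhibition; on this read-out higher numbers stand for weaker inhibition and lower numbers for stronger inhibition. Compound 1 `C/C(=C\COC(=O)NC(C)(C)C)C1=CC(=O)C(C)(C)O1` gives 7.1 ug/mL. For the measured compounds named here, compound 2 `COc1ccc(/C=C/C=C(\C)C2=CC(=O)C(C)(C)O2)cc1` gives 25 ug/mL, and compound 3 `C/C(=C\C=C\c1ccccc1)C1=CC(=O)C(C)(C)O1` gives 15 ug/mL; the only single-point step measured so far, a 1.7-fold lower number from compound 2 to compound 3 (0.22 log units; within the scatter), stays within the scatter. Compound 1 therefore holds the lowest of the three numbers, with the gap to compound 3 and the larger gap to compound 2 both beyond the scatter.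

Compound 4 `C/C(=C\COC(=O)NC1CCCCC1)C1=CC(=O)C(C)(C)O1` has not yet been measured in this assay. Against compound 1 the change is cyclohexyl in place of tert-butyl on an amide-type nitrogen. Going by the values given here, no measured step touches this part of the molecule: the one step on record alters an aromatic substituent on a different side chain and carries no information about the carbamate end. With nothing to point either way, the expectation is a step of no more than the scatter, expected as a 1.1-fold higher number from compound 1 to compound 4 (0.02 log units; within the scatter). Compound 4 is accordingly estimated at 7.5 ug/mL, with a range from 3 ug/mL to 19 ug/mL.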

Compound 4, half-maximal inhibitory concentration: 13 ug/mL
Beside the measured number, compound 4's estimate is 1.7-fold (0.24 log units) below it, within the range that was stated.
By their numbers in this assay, from the lowest: compounds 1, 4, 3 and 2 (each within the scatter of the next, the first and the last beyond it).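

In this assay, for the compounds shown here, the change from tert-butyl to cyclohexyl on an amide-type nitrogen gives a 1.8-fold higher number from compound 1 to compound 4 (0.26 log units; within the scatter) and so stays within the scatter; this is the first measured step at the carbamate end of the series. On this nitrogen, the six-membered non-aromatic ring of carbon only therefore gives a number that cannot be told apart from that of the tert-butyl group. No available evidence bears on this step.

Still open, on these data alone, is whether a longer straight alkyl chain, a phenyl ring or a carboxylic acid-bearing chain on the same nitrogen would shift the number beyond the scatter. Also open, as far as these compounds go, is the effect of a methyl group in place of the amide hydrogen.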